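The source may report more compounds than this note shows. Statements on the series, on what has been measured and on what is new or still open speak of the compounds shown alone.

Working notes on the series. Of the compounds shown here, three sharing one core have so far been tested in a functional assay on NCI-H322M cells (Homo sapiens) for inhibition, read by sulforhodamine B assay, with a stated time of 48 h, tested at 10 uM; on this read-out lower numbers stand for less inhibition and higher numbers for more inhibition at the one concentration tested (going by the name of the read-out). Compound 1 `Brc1cn2ccnc2c(-c2ccc3ncn(C4CCCCC4)c3c2)n1` gives 18.1%. Compound 2 `COc1ccc(-c2cn3ccnc3c(-c3ccc4ncn(C5CCCCC5)c4c3)n2)cc1` gives 31.5%, and compound 3 `O=Cc1ccc(-c2cn3ccnc3c(-c3ccc4ncn(C5CCCCC5)c4c3)n2)cc1` gives 11.2%. On these numbers compound 3 stands lowest of the three, but its separation from compound 1 is only a number 6.9 percentage points lower from compound 1 to compound 3 (within the scatter), so those two cannot be ordered; against compound 2 the gap is a number 20.3 percentage points lower from compound 2 to compound 3 (beyond the scatter), which does separate them. The remaining measured step, a number 13.4 percentage points higher from compound 1 to compound 2 (beyond the scatter), is of comparable size.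

Compound 4 `c1ccc2c(-c3cn4ccnc4c(-c4ccc5ncn(C6CCCCC6)c5c4)n3)cccc2c1` is not yet measured. It differs from compound 3 in one place: naphthalen-1-yl in place of 4-formylphenyl on an aromatic carbon. Within the data shown here, no measured pair exchanges one aryl group for another at this position, so the steps that bear on it are the two that alter the same position, a number 6.9 percentage points lower from compound 1 to compound 3 (within the scatter) and a number 20.3 percentage points lower from compound 2 to compound 3 (beyond the scatter). All three measured variants at this position fall within a narrow band, and a further aryl group is expected to stay inside that band. The step expected in this assay is therefore a number 8.8 percentage points higher from compound 3 to compound 4 (within the scatter), not beyond the scatter, leaning upward only because compound 2 with an aryl group there reaches 31.5%. Compound 4 is estimated at 20%, with a range from 8% to 38%.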

Compound 4, a percentage reported as inhibition, at one concentration (the size of the read-out at that concentration, not a potency): 4.74%
The estimate for compound 4 lay 15.3 percentage points above the measured number; measured number outside the range, below it.
By their numbers in this assay, from the lowest: compounds 4, 3 and 1 (each within the scatter of the next, the first and the last beyond it); then compound 2.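

In this assay a large aryl group at this position does not by itself go with a higher number: naphthalen-1-yl in place of 4-methoxyphenyl gives a number 26.8 percentage points lower from compound 2 to compound 4 (beyond the scatter) and is the largest step seen so far in the series, which leaves compound 2 alone at the top of the four. Naphthalen-1-yl in place of bromo gives a number 13.4 percentage points lower from compound 1 to compound 4 (beyond the scatter) and so separates from bromo, something 4-formylphenyl did not do, while naphthalen-1-yl in place of 4-formylphenyl gives a number 6.5 percentage points lower from compound 3 to compound 4 (within the scatter) and those two cannot be ordered. The series holds no measurement that accounts for these differences at this position.

As far as these compounds go, how an amine, a carboxylic acid or a longer chain would read on this aromatic carbon remains open, as does whether naphthalen-2-yl would read like naphthalen-1-yl. From the compounds shown here alone, all four compounds also keep the rest of the structure unchanged, so it is open whether this order of groups would hold with a different group elsewhere on the shared core, or at a concentration other than the single one tested here.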